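A Hydroxy Exchange at the Limit of Solubility

The source may hold more compounds than are shown below. What is called first, only, known or untested is meant among the compounds shown, and "the series" means these compounds.

Measured so far in a physicochemical assay for solubility, in phosphate buffer, at pH 6.8; a lower number here means a less soluble compound, a higher number a more soluble compound:
Compound 1 `Cc1cc(-c2ccc(N3C(=O)C(O)=C(C(=O)C(C)(C)C)C3c3ccccc3OCCO)cc2)on1`: > 50000 nM, a limit of the assay
Compound 2 `CC(C)(C)C(=O)C1=C(O)C(=O)N(c2ccc(-c3ccsc3)cc2)C1c1ccccc1OCCO`: > 50000 nM, a limit of the assay

Compound 2 has no exact number, only its limit of > 50000 nM. Compound 3 `C[S+]([O-])CCOc1ccccc1C1C(C(=O)C(C)(C)C)=C(O)C(=O)N1c1ccc(-c2ccsc2)cc1` differs from it in one place: a group of 3 heavy atoms (1 carbon, 1 oxygen, 1 sulfur; no ring) in place of one oxygen atom, on a saturated chain carbon, two bonds along the chain from an oxygen on an aromatic ring. The hydroxy leaves a saturated chain carbon, two bonds along the chain from an oxygen on an aromatic ring. Within the data shown here, the only measured step is a step that the two limits leave unreadable from compound 1 to compound 2, made on an aromatic carbon rather than on this chain, and it offers no size to carry over. What remains is the limit of > 50000 nM in this assay, at which 2 of the 2 values shown sit, shared by compound 1 and compound 2. On that ground, no step beyond the usual scatter is expected in this assay, and neither direction is favoured. The expected step is a number no higher from compound 2 to compound 3 (the limit leaves the size open). Compound 3 is estimated at 50000 nM, with an expected range of 20000 nM to 120000 nM, and it may well be reported only as a limit.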

Compound 3, solubility: > 50000 nM
Compound 3: no number, only a limit; the forecaster's own chance of this, stated with the estimate: 75%; the middle value lies on the limit itself.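

Among these compounds, compound 3 sits at a limit of this assay, as compound 2 does, and no step between compound 2 and compound 3 can be read. The compounds shown leave open how their true values compare, because all of them share one reading: the limit of > 50000 nM in this assay, at which 3 of the 3 values shown sit.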